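The source may report more compounds than this note shows. Statements on the series, on what has been measured and on what is new or still open speak of the compounds shown alone.

Compound 1 `Cc1ccccc1-c1nn(-c2ccc(Br)cc2)cc1CNCCN1CCN(C)CC1` carries a 4-bromophenyl group on the aromatic nitrogen of its five-membered ring. In an ADME assay on Huh-7 cells (Homo sapiens) for cytotoxicity (on this read-out lower numbers stand for higher toxicity in this test and higher numbers for lower toxicity in this test), compound 1 gives 9600 nM. Compound 2 `Cc1ccccc1-c1nn(-c2ccc(OC(F)(F)F)cc2)cc1CNCCN1CCN(C)CC1` keeps the shared core and differs only in the substituent on that phenyl ring; in this assay compound 2 gives 17000 nM. Going by the values given here, the change between them, a 1.8-fold higher number from compound 1 to compound 2 (0.25 log units; within the scatter), is the only step measured so far. Among the compounds with values here, compound 2 thus sits at one end of the two numbers known, but the gap to compound 1 is within the scatter, so the two cannot be told apart on toxicity.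

Compound 3 `Cc1ccccc1-c1nn(-c2ccccc2Cl)cc1CNCCN1CCN(C)CC1` has not yet been measured. Compared with compound 2 it shows (2-chlorophenyl in place of 4-(trifluoromethoxy)phenyl on an aromatic nitrogen). Within the data shown here, the one measured step, from compound 1 to compound 2, swapped a substituent on the same phenyl ring and stayed within the scatter, and nothing else bears on a change at this position. The step of a 1.4-fold lower number from compound 2 to compound 3 (0.15 log units; within the scatter) is therefore expected to be small, with no direction beyond the scatter. For compound 3 in this assay the estimate is 12000 nM, within a range from 5000 nM to 30000 nM.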

Compound 3, half-maximal cytotoxic concentration: > 20000 nM
Compound 3: only a limit was reported; the forecaster's own chance of this, stated with the estimate: 10%; middle value at least 1.6-fold (0.22 log units) away from the limit.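

Swapping the whole aryl group on the aromatic nitrogen for 2-chlorophenyl gives, against the 4-(trifluoromethoxy)phenyl of compound 2, an at least 1.1-fold higher number from compound 2 to compound 3 (0.07 log units; that floor lies within the scatter), so on this floor alone that swap cannot be told apart from no change at all in this assay. Against the 4-bromophenyl of compound 1, the same place gives an at least 2.0-fold higher number from compound 1 to compound 3 (0.31 log units; beyond the scatter), the first step shown that clears the scatter, and so the first sign that the group on this nitrogen can move the read-out toward lower toxicity in this test. Compound 3 is recorded only as a limit of the assay, not as a number, so both steps are floors and their true sizes stay unknown: the limit of > 20000 nM in this assay, at which 1 of the 3 values shown sits.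

Compound 3 differs from compound 1 both in the halogen and in where it sits on the phenyl ring, so the compounds shown cannot say which of the two matters. A 4-chlorophenyl or 2-bromophenyl group on this nitrogen would separate them, and an unsubstituted phenyl or a 4-aminophenyl group would show whether any halogen is needed at all.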